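The source may hold more compounds than are shown below. What is called first, only, known or untested is meant among the compounds shown, and "the series" means these compounds.

Measured in a functional assay on BGC-823 cells (Homo sapiens) for antiproliferative activity, read by MTT assay, with a stated time of 48 h; a higher number here means a weaker inhibitor, a lower number a stronger inhibitor:
compound 1 `Fc1ccccc1N1CCN(Cn2nc(-c3ccc4c(c3)OCCO4)oc2=S)CC1` gives > 50000 nM, a limit of the assay
compound 2 `O=[N+]([O-])c1ccc(N2CCN(Cn3nc(-c4ccc5c(c4)OCCO5)oc3=S)CC2)cc1` gives > 50000 nM, a limit of the assay

Compound 2 sits at the limit of > 50000 nM in this assay, at which 2 of the 2 values shown sit. The step that the two limits leave unreadable from compound 1 to compound 2 cannot be read. Compound 3 `S=c1oc(-c2ccc3c(c2)OCCO3)nn1CN1CCN(c2ccccn2)CC1` differs from compound 2 by pyridin-2-yl in place of 4-nitrophenyl on an amine nitrogen in a ring. Within the data shown here, no measured step bears on this change; both values shown are limits. Compound 3 is therefore expected to stay near the same limit, with an estimate of 60000 nM (range 20000 nM to 200000 nM). The implied step that the limit leaves unreadable from compound 2 to compound 3 is expected to lie within the scatter.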

Compound 3, half-maximal inhibitory concentration: 25900 nM
Compound 3: the middle estimate sits 2.3-fold (0.36 log units) above what was measured; the range from low to high includes it.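

In this assay, among these compounds, pyridin-2-yl on the amine nitrogen in the ring gives the only value shown that is a number and not a limit, with an at least 1.9-fold lower number from compound 2 to compound 3 (0.28 log units; that floor lies within the scatter) and an at least 1.9-fold lower number from compound 1 to compound 3 (0.28 log units; that floor lies within the scatter). From the compounds shown here alone, both steps are floors, so their true size stays unknown, and the step between compound 1 and compound 2 cannot be read. Compound 1 and compound 2 stay at a limit of the assay: the limit of > 50000 nM in this assay, at which 2 of the 3 values shown sit.

The compounds shown leave open whether the ring nitrogen of pyridin-2-yl matters here. An unsubstituted phenyl or a pyrimidin-2-yl at this place would test that.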